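The source may report more compounds than this note shows. Statements on the series, on what has been measured and on what is new or still open speak of the compounds shown alone.

Among the measured compounds shown here, in an in vivo ADME assay on the whole organism (plasma, strain Sprague-Dawley) for pharmacokinetics, with Rattus norvegicus as the target (a higher number here means faster removal of the compound, a lower number slower removal), three compounds carry numbers so far. Compound 1 `CN1CCc2cc(N3CC[C@H](NS(=O)(=O)/C=C/c4ccc(Cl)s4)C3=O)ccc2C1` stands at 26 mL/min/kg on this measure. Compound 3 `O=C1[C@@H](NS(=O)(=O)c2ccc3cc[nH]c3c2)CCN1c1ccc2c(c1)CCNC2` stands at 12 mL/min/kg on the same measure. Compound 2 `O=C1[C@@H](NS(=O)(=O)c2ccc3cc(Cl)ccc3c2)CCN1c1ccc2c(c1)CCNC2` stands at 4 mL/min/kg as the lowest of the three, and its gaps to compound 1 and compound 3 both lie beyond the scatter. No two of these compounds differ in one place only, so no measured step speaks directly to the next change.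

Compound 4 `O=C1[C@@H](NS(=O)(=O)c2ccc3cc(Cl)ccc3c2)CCN1c1ccc2c(c1F)CCNC2` is compound 2 with a single edit (fluoro in place of hydrogen on an aromatic carbon) that places fluoro in place of hydrogen on an aromatic carbon, ortho to a fused ring and ortho to a large group. For the measured compounds named here, none of the three measured compounds carries fluoro at this place, so the data give no precedent for its size or direction. With compound 2 at 4 mL/min/kg as the only anchor, the expectation stays close to that number, with no shift beyond the scatter. The expected step of a 1.3-fold higher number from compound 2 to compound 4 (0.10 log units; within the scatter) is small and is estimated to stay within the scatter. Compound 4 is expected at 5 mL/min/kg within an estimated range of 2.5 mL/min/kg to 10 mL/min/kg on the this assay scale.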

Compound 4, clearance: 2.1 mL/min/kg
The estimate for compound 4 lay 2.4-fold (0.38 log units) above the measured number, and the stated range ends above it.
By their numbers in this assay, from the lowest: compounds 4 and 2 (each within the scatter of the next); then compound 3; then compound 1.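

In this assay, among the compounds shown here, fluoro in place of hydrogen on an aromatic carbon, ortho to a fused ring and ortho to a large group, gives a 1.9-fold lower number from compound 2 to compound 4 (0.28 log units; within the scatter) and thus provides the first measured step that differs in one place. On this reading, the position accepts fluoro without a change in the read-out that can be told from the scatter, so the single heavy atom added here leaves compound 4 and compound 2 indistinguishable on this measure. No measured information bears on the reason for this outcome, and the step therefore stands only as an observation at this position in this one compound pair.

Going by these compounds, it remains open whether a larger or different group at this same place, such as chloro, methoxy, trifluoromethyl, nitrile or an amine, would also stay within the scatter or would produce a clear step. On these data alone, it also remains open whether fluoro at this place would read the same on the core of compound 1 or compound 3, where the rest of the molecule differs from compound 2.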